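Aryloxy to benzyl swap at the acetal side chain

The source may hold more compounds than are shown below. What is called first, only, known or untested is meant among the compounds shown, and "the series" means these compounds.

For the measured compounds named here, compound 3 `COc1ccccc1OC(C)(C)C1OCC(C/C=C\CCC(=O)O)C(c2cccnc2)O1` gives 60 nM in an assay for inhibition of Thromboxane-A synthase (Homo sapiens), using microsomes (a lower number here means a stronger inhibitor, a higher number a weaker inhibitor), and stands highest of the three numbers so far. Its nearest neighbour is compound 1 `O=C(O)CC/C=C\CC1COC(c2ccc(C(F)(F)F)cc2)OC1c1cccnc1` with 44 nM, within the scatter of compound 3; the furthest is compound 2 `CSc1ccc(OC(C)(C)C2OCC(C/C=C\CCC(=O)O)C(c3cccnc3)O2)c([N+](=O)[O-])c1` with 22 nM, which sits beyond the scatter below compound 3.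

Compound 4 `CC(C)(Cc1ccc(F)cc1)C1OCC(C/C=C\CCC(=O)O)C(c2cccnc2)O1` differs from compound 3 by 4-fluorobenzyl in place of 2-methoxyphenoxy on a saturated chain carbon bound to two saturated chain carbons and a saturated ring carbon. Going by the values given here, the one measured step at this position, a 2.7-fold higher number from compound 2 to compound 3 (0.44 log units; beyond the scatter), swapped one aryloxy group for another and moved the number only modestly. Among the compounds with values here, the present change goes further, dropping the oxygen link and the methoxy group for a 4-fluorobenzyl, and no measured pair covers that kind of exchange. Given the modest size of the only step at this site, a step within or just beyond the scatter is expected in either direction, with no clear lean.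

Compound 4 is therefore estimated at 50 nM, range 15 nM to 200 nM, meaning an expected step of a 1.2-fold lower number from compound 3 to compound 4 (0.08 log units; within the scatter).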

Compound 4, half-maximal inhibitory concentration: 45 nM
Beside the measured number, compound 4's estimate is 1.1-fold (0.05 log units) above it; measured number inside the range.
By their numbers in this assay, from the lowest: compounds 2, 1, 4 and 3 (each within the scatter of the next, the first and the last beyond it).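

In this assay, 4-fluorobenzyl in place of 2-methoxyphenoxy gives a 1.3-fold lower number from compound 3 to compound 4 (0.12 log units; within the scatter) and so does not shift the number beyond the scatter. The earlier step at this position, a 2.7-fold higher number from compound 2 to compound 3 (0.44 log units; beyond the scatter), kept the oxygen link and exchanged one aryloxy group for another, whereas this one shows that the link can go, with hydrogen-bond acceptors in the group falling from 2 to 0, and the number still holds within the scatter. Nothing available explains why the two groups read alike.

The oxygen link, the methoxy group and the fluorine all change in this one step, so their separate contributions stay unresolved; 4-fluorophenoxy would separate the link from the ring substituent. Going by these compounds, whether this position also accepts an amine or a carboxylic acid on the ring, or a longer chain before it, remains open.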